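Pyrrolidin-1-yl in place of morpholin-4-yl: working notes

The source may hold more compounds than are shown below. What is called first, only, known or untested is meant among the compounds shown, and "the series" means these compounds.

Among the measured compounds shown here, in a functional assay on A549 cells (Homo sapiens) for inhibition, read by MTT assay, with a stated time of 48 h (on this read-out lower numbers stand for stronger inhibition and higher numbers for weaker inhibition), compound 1 (`Cn1c(/C=C2\SC(=O)N(CC(=O)N3CCOCC3)C2=O)nc2ccccc21`) gives 38500 nM, the only actual number so far. For compound 2 (`CC(C)n1c(/C=C2\SC(=O)N(CC(=O)N3CCOCC3)C2=O)nc2ccccc21`) the reading is a limit, > 50000 nM. Compound 3 (`Cn1c(/C=C2\SC(=O)N(CC(=O)N3CCCC3)C2=O)nc2ccccc21`) differs from compound 1 on a carbonyl carbon: pyrrolidin-1-yl in place of morpholin-4-yl on a carbonyl carbon. For the measured compounds named here, the only measured step, an at least 1.2-fold higher number from compound 1 to compound 2 (0.11 log units; that floor lies within the scatter), lies on an aromatic nitrogen and does not touch this place, so it gives no guide to size or direction. No shift beyond the scatter is therefore expected in this assay. The expected change is a 1.2-fold lower number from compound 1 to compound 3 (0.08 log units; within the scatter). Compound 3 is estimated at 32000 nM, with an expected range of 13000 nM to 50000 nM.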

Compound 3, half-maximal inhibitory concentration: > 50000 nM
Compound 3: a limit, no number (the forecaster's own chance of this, stated with the estimate: 25%); middle value at least 1.5-fold (0.19 log units) from the limit.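

In this assay, the change at this carbonyl carbon gives an at least 1.2-fold higher number from compound 1 to compound 3 (0.11 log units; that floor lies within the scatter), so the position now has a reading of its own, though only as a floor. Compound 3 carries a limit and not a number, and the series now gathers at one reading: the limit of > 50000 nM in this assay, at which 2 of the 3 values shown sit. Whether pyrrolidin-1-yl moves the number at all relative to morpholin-4-yl stays unsettled.

The compounds shown leave open whether piperidin-1-yl, or a primary amine with a longer chain, on the same carbonyl carbon would give an actual number.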